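Bromine on the pyridine of a sub-nanomolar amide hydrolase inhibitor

This account rests on a few compounds, and the source may have more. Where it says the series, first, only, none or still open, it means among the compounds named here.

Of the compounds shown here, two have been measured so far. Compound 1 `O=C(CCCCCCc1ccccc1)c1nnc(-c2cccc(Br)n2)s1` gives 37 nM in an assay for inhibition of Fatty-acid amide hydrolase 1 (Rattus norvegicus); on this read-out lower numbers stand for stronger inhibition and higher numbers for weaker inhibition. Compound 2 `O=C(CCc1ccc(-c2ccccc2)cc1)c1nnc(-c2ccccn2)o1` gives 0.3 nM in this assay, the lowest of the two numbers, and the gap to compound 1 is far beyond the scatter of the method. Among the measured compounds shown here, compound 1 and compound 2 differ in more than one place, so their two values show only that compound 2 inhibits much more strongly, not what any single change does.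

Compound 3 `O=C(CCc1ccc(-c2ccccc2)cc1)c1nnc(-c2cccc(Br)n2)o1` has not yet been measured. It differs from compound 2 by bromo in place of hydrogen on an aromatic carbon; cut one bond further out, the change reads pyridin-2-yl to 6-bromopyridin-2-yl. For the measured compounds named here, no measured pair isolates this change, and compound 1, which already carries the 6-bromopyridin-2-yl, cannot be compared directly because of its other differences.

With compound 2 at 0.3 nM, the step from compound 2 to compound 3 is expected to be small, a 2.0-fold higher number from compound 2 to compound 3 (0.30 log units; within the scatter), most likely within the scatter or a slight weakening. Compound 3 is therefore estimated at 0.6 nM, with a likely range from 0.15 nM to 3 nM.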

Compound 3, inhibition constant: 3.6 nM
Compound 3: middle estimate off by 6.0-fold (0.78 log units), on the low side; measured number above the stated range.
By their numbers in this assay, from the lowest: compound 2; then compound 3; then compound 1.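

Among the compounds shown here, the pair gives the first clean reading of this position: in this assay, the change from pyridin-2-yl to 6-bromopyridin-2-yl, with the bromo next to the ring nitrogen, gives a 12-fold higher number from compound 2 to compound 3 (1.08 log units; beyond the scatter). Neither compound 1 nor compound 2 could show this alone, since they differ in more than one place, so the position now stands as one where a single heavy atom in place of hydrogen changes the number well beyond the scatter. Compound 3 still gives 3.6 nM with the bromo in place, so on this one pair the change weakens inhibition without abolishing it, and nothing among the data offers an explanation for the size of the step.

The compounds shown leave open whether this step belongs to bromo in particular or would also appear with a smaller atom such as fluorine, or with a group such as methyl, methoxy or an amine at the same carbon. They also leave open whether the bromo costs as much on the core and the longer chain of compound 1, as that compound has no partner differing from it in this one place.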